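Enantiomer of the hydroxamic acid: mirror-image step

The compounds below may be only part of what the source reports. "The series", "measured", "known", "first", "only" and "open" are said of these compounds alone.

For the measured compounds named here, compound 2 `CC(C)=CCCC1=CC[C@@H](C(=O)NO)[C@H](c2ccccc2)C1` is the only compound of the pair with a number in an assay on isolated protein for inhibition of Apoptosis regulator Bcl-2 (Homo sapiens), read by fluorescence polarization, with stated times of 5 min and 10 min (a lower number here means a stronger inhibitor, a higher number a weaker inhibitor), where compound 2 gives 700 nM. Compound 1 `CC(C)=CCCC1=CC[C@H](C(=O)Nc2ccc(O)cc2)[C@@H](c2ccccc2)C1` sits at a limit of this assay with > 23000 nM. Compound 3 `CC(C)=CCCC1=CC[C@H](C(=O)NO)[C@@H](c2ccccc2)C1` is not yet measured; (the two compounds have the same atoms and bonds and differ only in configuration as drawn: 2 of 2 stereo elements differ (all stereocentres are inverted: mirror images); a stereocentre at a saturated ring carbon is drawn R in compound 2 and S in compound 3; a stereocentre at a saturated ring carbon is drawn R in compound 2 and S in compound 3). Going by the values given here, no measured step of this kind is at hand, so the direction is open; the expected step from compound 2 to compound 3 is a 5.0-fold higher number from compound 2 to compound 3 (0.70 log units; beyond the scatter), towards a weaker inhibitor. Compound 3 is expected near 3500 nM, within 500 nM to 23000 nM.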

Compound 3, inhibition constant: 600 nM
Compound 3: the middle estimate sits 5.8-fold (0.77 log units) above what was measured, within the range that was stated.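

In this assay, inverting both stereocentres gives a 1.2-fold lower number from compound 2 to compound 3 (0.07 log units; within the scatter), so this mirror-image pair shows no readable preference for either configuration. Hydroxy in place of 4-hydroxyphenyl on the amide-type nitrogen, in the shared configuration of compound 1 and compound 3, gives an at least 38-fold lower number from compound 1 to compound 3 (1.58 log units; beyond the scatter). The value for compound 1 is a limit, not a number: the limit of > 23000 nM in this assay, at which 1 of the 3 values shown sits.

Still open, on these data alone, is whether a carboxylic acid or a methyl ester can replace the hydroxamic acid. As far as these compounds go, the effect of a longer chain on the shared core is also open.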